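A few compounds are considered here, and "the series" means these few. Any claim that something is new, unique, unknown or untested is made for them only; others in the source may bear on it.

Compound 1, `N#Cc1cccnc1N1CCN(CC/C(=N\O)c2ccccc2)CC1`, and compound 2, `O/N=C(\CCN1CCN(c2ncccn2)CC1)c1ccccc1`, share the oxime and the piperazine-linked aryl part and differ only at the amine nitrogen in the ring. In a functional assay on HEK293 cells with D(4) dopamine receptor (Homo sapiens) as the target, read by FLIPR (a higher number here means that more compound is needed for the effect, a lower number that less compound is needed), compound 1 gives 18 nM, and compound 2 gives 39.2 nM. Within the data shown here, the one measured step, a 2.2-fold higher number from compound 1 to compound 2 (0.34 log units; beyond the scatter), is the only comparison available, so compound 2 stands at the higher of the two numbers in this assay, with compound 1 as its only neighbour.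

Compound 3, `CCO/N=C(\CCN1CCN(c2ncccn2)CC1)c1ccccc1`, is the next member. Its change from compound 2 is ethyl in place of hydrogen on an oxygen, a change at the oxygen of the oxime, away from the site where compound 1 and compound 2 differ. Among the measured compounds shown here, no measured step touches this oxygen, so nothing in the two numbers so far bears directly on it; the step from compound 1 to compound 2 only shows that a modest change is what a single substitution has produced here. The expectation for compound 3 is therefore a step of a 1.5-fold higher number from compound 2 to compound 3 (0.18 log units; within the scatter) with no firm direction, and compound 3 is estimated at 60 nM within 15 nM to 250 nM.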

Compound 3, half-maximal effective concentration: 615 nM
The estimate for compound 3 lay 10-fold (1.01 log units) below the measured number, and the stated range ends below it.
By their numbers in this assay, from the lowest: compound 1; then compound 2; then compound 3.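

In this assay this oxygen, whose other neighbour is a double-bonded nitrogen, responds far more strongly to substitution than the earlier pair suggested: ethyl in place of hydrogen gives a 16-fold higher number from compound 2 to compound 3 (1.20 log units; beyond the scatter), whereas the change on the amine nitrogen in the ring gave only a 2.2-fold higher number from compound 1 to compound 2 (0.34 log units; beyond the scatter). The hydrogen on this oxygen therefore cannot be replaced by ethyl without a large loss in this pyrimidin-2-yl series, at least as far as this single pair shows, and the two substitutions seen so far do not carry equal weight in the series. Nothing available explains the size of this step.

Still open, going by these compounds, is whether the step grows with the size of the group on this oxygen, which a methyl, or a longer chain such as propyl, would help to settle, and whether a group ending in an amine or a carboxylic acid would behave like ethyl. On these data alone, it is equally open whether hydroxy to ethoxy costs as much on the 3-cyanopyridin-2-yl compound, compound 1, as it does here.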